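The source may hold more compounds than are shown below. What is called first, only, known or untested is meant among the compounds shown, and "the series" means these compounds.

Compound 1 `Cc1nc(-c2cccnc2)sc1-c1nnc(Cc2ccccc2)o1` in an ADME assay on HCT-116 cells (Homo sapiens) for cytotoxicity, read by MTT assay (on this read-out lower numbers stand for higher toxicity in this test and higher numbers for lower toxicity in this test), gives > 100 ug/mL, which is a limit of the assay and not a number.
Compound 2 `Cc1nc(-c2cccnc2)sc1-c1nnc(-c2ccccc2)o1` in this assay gives > 100 ug/mL, again a limit.
Compound 3 `Cc1nc(-c2cccnc2)sc1-c1nnc(-c2ccc(Cl)cc2)o1` in this assay gives > 100 ug/mL, again a limit.

Compound 2 therefore stands only at a limit, and the two other values shown sit at the same limit, (the limit of > 100 ug/mL in this assay, at which 3 of the 3 values shown sit). The step to compound 4 `Cc1ccc(-c2nnc(-c3sc(-c4cccnc4)nc3C)o2)cc1` is methyl in place of hydrogen on an aromatic carbon. Three measured steps are at hand: a step that the two limits leave unreadable from compound 1 to compound 2, a step that the two limits leave unreadable from compound 1 to compound 3 and a step that the two limits leave unreadable from compound 2 to compound 3. Because all three values sit at the limit of > 100 ug/mL in this assay, at which 3 of the 3 values shown sit, none of these steps can be read in size or direction, so they give no guidance for a small group entering on an aromatic carbon, which is the kind of change made here. With no readable effect from any measured step, compound 4 is expected to remain at the limit, with an estimated value of 150 ug/mL in this assay, between 80 ug/mL and 400 ug/mL. The expected step that the limit leaves unreadable from compound 2 to compound 4 is thus none beyond the scatter, and most likely only a limit will be reported.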

Compound 4, half-maximal cytotoxic concentration: > 100 ug/mL
Compound 4: a limit, no number; the forecaster's own chance of this, stated with the estimate: 85%; the middle value is on the limit's open side.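

Compound 4 also ends at a limit and not a number, so its steps from compound 1, compound 2 and compound 3 cannot be read in size or direction: the limit of > 100 ug/mL in this assay, at which 4 of the 4 values shown sit.

The compounds shown leave open at what concentration any of them becomes toxic in this assay, and whether these changes differ in effect.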